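A few compounds are considered here, and "the series" means these few. Any claim that something is new, unique, unknown or untested is made for them only; others in the source may bear on it.

Compound 1 `c1ccc(COc2ccccc2Nc2ncnc3cc4c(cc23)OCCOCCOCCO4)cc1` gives 6940 nM in a functional assay on A549 cells (Homo sapiens) for antiproliferative activity, read by MTT assay, with a stated time of 72 h (on this read-out higher numbers stand for weaker inhibition and lower numbers for stronger inhibition), the lowest of the two numbers on hand. Compound 2 `c1ccc(COc2ccc(Nc3ncnc4cc5c(cc34)OCCOCCO5)cc2)cc1` gives 43900 nM in this assay; these two compounds differ in more than one place, so their values are simply set side by side and not traced to a single change. Compound 3 `O=[N+]([O-])c1ccc(COc2ccccc2Nc2ncnc3cc4c(cc23)OCCOCCOCCO4)cc1` carries nitro in place of hydrogen on an aromatic carbon relative to compound 1. Among the measured compounds shown here, with no measured step of this kind on hand, the step of a 1.4-fold lower number from compound 1 to compound 3 (0.14 log units; within the scatter) is expected to stay near the scatter, leaning if anything toward stronger inhibition. Compound 3 is therefore estimated at 5000 nM, within 1500 nM to 16000 nM.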

Compound 3, half-maximal inhibitory concentration: 29900 nM
Compound 3: middle estimate off by 6.0-fold (0.78 log units), on the low side; measured number above the stated range.
By their numbers in this assay, from the lowest: compound 1; then compounds 3 and 2 (each within the scatter of the next).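

In this assay, going from benzyloxy to (4-nitrobenzyl)oxy gives a 4.3-fold higher number from compound 1 to compound 3 (0.63 log units; beyond the scatter) and so weakens inhibition, a modest step but one beyond the scatter. Among the compounds shown here, this is the first change at a single place on hand, and it shows that this position, para to a large group, does not take nitro without a loss. Nothing on hand explains this loss.

From the compounds shown here alone, whether the loss belongs to nitro alone remains open, as an amine, a methoxy group or a fluorine at the same carbon would tell. Going by these compounds, whether the same step holds on the core of compound 2 also remains open.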